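Hydrazone aryl variation on a fixed diaryl ether core

The source may report more compounds than this note shows. Statements on the series, on what has been measured and on what is new or still open speak of the compounds shown alone.

Compound 2, `CN(C)CCn1cnnc1-c1cc(Oc2ccc(NC(=O)N/N=C/c3cc(Br)c(O)c(Br)c3)cc2F)ccn1`, carries a 3,5-dibromo-4-hydroxyphenyl on the hydrazone carbon. In a functional assay on A549 cells (Homo sapiens) for cytotoxicity, read by MTT assay, with a stated time of 72 h (a lower number here means a stronger inhibitor, a higher number a weaker inhibitor), compound 2 reports only the limit > 100000 nM. Compound 1, `CN(C)CCn1cnnc1-c1cc(Oc2ccc(NC(=O)N/N=C/c3cccc(O)c3)cc2F)ccn1`, with 3-hydroxyphenyl in that position, likewise gives only the limit > 100000 nM in this assay. Between them the step that the two limits leave unreadable from compound 1 to compound 2 cannot be read, as both sit at the limit of > 100000 nM in this assay, at which 2 of the 3 values shown sit. Compound 3, `CN(C)CCn1cnnc1-c1cc(Oc2ccc(NC(=O)N/N=C/c3ccccc3O[N+](=O)[O-])cc2F)ccn1`, with 2-(nitrooxy)phenyl, gives 1200 nM in this assay, so the steps of an at least 83-fold lower number from compound 1 to compound 3 (1.92 log units; beyond the scatter) and an at least 83-fold lower number from compound 2 to compound 3 (1.92 log units; beyond the scatter) are large.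

Compound 4, `CN(C)CCn1cnnc1-c1cc(Oc2ccc(NC(=O)N/N=C/c3ccc(O)cc3O)cc2F)ccn1`, is the next variation: 2,4-dihydroxyphenyl in place of 3,5-dibromo-4-hydroxyphenyl on a carbon with a double bond to nitrogen. Among the measured compounds shown here, no measured step bears directly on hydroxyl placement alone; the two hydroxyphenyl analogues, compound 1 and compound 2, both sit at the limit, and only the nitrooxy analogue compound 3 departs from it. The 2,4-dihydroxyphenyl is expected to behave like the other hydroxyphenyls, so no step beyond the scatter is expected in this assay for compound 4, with the step that the limit leaves unreadable from compound 2 to compound 4 expected to stay within scatter of the limit. Compound 4 is estimated at 150000 nM in this assay, within 50000 nM to 500000 nM, most likely reported as a limit only.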

Compound 4, half-maximal inhibitory concentration: 12700 nM
Beside the measured number, compound 4's estimate is 12-fold (1.07 log units) above it; measured number outside the range, below it.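

The 2,4-dihydroxyphenyl of compound 4 shows that a hydroxyl-bearing phenyl on this carbon does not by itself leave a compound at the limit in this assay, with an at least 7.8-fold lower number from compound 1 to compound 4 (0.89 log units; beyond the scatter) and an at least 7.8-fold lower number from compound 2 to compound 4 (0.89 log units; beyond the scatter). Going by these compounds, both steps start from a limit, so their full size is unknown, and the step between those two limits cannot be read: the limit of > 100000 nM in this assay, at which 2 of the 4 values shown sit. The hydroxyl-bearing group still does not match the 2-(nitrooxy)phenyl, with an 11-fold higher number from compound 3 to compound 4 (1.02 log units; beyond the scatter), which leaves compound 3 the strongest of the four.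

The compounds shown do not separate the effect of hydroxyl number from that of hydroxyl placement. On these data alone, it also remains open how an amine or a carboxylic acid on this phenyl would compare with the hydroxyl groups of compound 4.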